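The source may report more compounds than this note shows. Statements on the series, on what has been measured and on what is new or still open speak of the compounds shown alone.

Measured compounds in a functional assay (aorta) for inhibition, with Rattus norvegicus as the target; on this read-out lower numbers stand for stronger inhibition and higher numbers for weaker inhibition:

compound 1, `CC1(C)CCN(C(=O)Nc2ccccc2)c2cc(C#N)ccc21`, gives 6700000 nM
compound 2, `CC(C)(C)c1ccc(C#N)cc1/N=C(/NC#N)Nc1cccnc1`, gives 1200000 nM
compound 3, `CC(C)(C)c1ccc(C#N)cc1NC(=O)Nc1ccccn1`, gives 25700000 nM

Compound 3 stands at the highest number of the three in this assay, that is, it is the weakest inhibitor shown. Its nearest neighbour by number is compound 1, whose value lies beyond the scatter of compound 3; compound 2 is furthest away, also beyond the scatter. All three compounds sit at the weak end of this read-out, so the whole set is far from potent.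

Compound 4, `CC(C)(C)c1ccc(C#N)cc1NC(=O)Nc1cnccn1`, is not yet measured. It differs from compound 3 in one place: pyrazin-2-yl in place of pyridin-2-yl on an amide-type nitrogen. Within the data shown here, no measured pair in the set shows a step of this kind, so there is no comparison to lean on; the ring change is a small one at a position far from the urea carbonyl, and nothing among compounds 1 to 3 points to a direction.

The expectation for compound 4 in this assay is therefore a step of a 1.2-fold lower number from compound 3 to compound 4 (0.07 log units; within the scatter) from compound 3, which is not expected to reach beyond the scatter. The estimate for compound 4 is 22000000 nM, with a range from 6000000 nM to 80000000 nM.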

Compound 4, half-maximal inhibitory concentration: 15300000 nM
Estimate against measurement, compound 4: 1.4-fold (0.16 log units) above; measured number inside the range.
By their numbers in this assay, from the lowest: compound 2; then compound 1; then compounds 4 and 3 (each within the scatter of the next).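

In this assay, among these compounds, putting pyrazin-2-yl in place of pyridin-2-yl on an amide-type nitrogen gives a 1.7-fold lower number from compound 3 to compound 4 (0.23 log units; within the scatter), the first step at this position that can be read. The change adds a second ring nitrogen and, by count, a second hydrogen-bond acceptor, yet the two compounds stay within the scatter of each other, so this read-out does not separate these two rings, and both compounds remain at the weak end of the set. No supporting data bear on this result, so it stands as an observation without an explanation.

As far as these compounds go, one step between two closely matched six-membered aromatic rings says little about how much this position can change the number, and whether any group placed here can move it beyond the scatter remains open. Also open, from the compounds shown here alone, are the effects of a pyridin-2-yl ring carrying an amine or a carboxylic acid, of a longer alkyl chain on the same nitrogen, and of the same ring change on the cyanoguanidine of compound 2.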